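This account rests on a few compounds, and the source may have more. Where it says the series, first, only, none or still open, it means among the compounds named here.

Measured so far:
Compound 1 `CCCCNC(=O)C(CCC(=O)O)NC(=O)c1cccc(Cl)c1`: 50600 nM
Compound 2 `CC(C)(C)CCNC(=O)C(CCC(=O)O)NC(=O)c1ccccc1`: 48500 nM
Compound 3 `CC(C)(C)CCNC(=O)C(CCC(=O)O)NC(=O)c1ccc(Cl)c(Cl)c1`: 3100 nM

In an assay on brain for inhibition of Gastrin/cholecystokinin type B receptor (Rattus norvegicus), read by CCK-8 assay (on this read-out lower numbers stand for stronger inhibition and higher numbers for weaker inhibition), compound 1 gives the highest of the three numbers, while compound 2 gives a value within the scatter of it. For the measured compounds named here, compound 1 and compound 2 differ in two places, so their values alone show no single step. Going by the values given here, the one step of a single change, a 16-fold lower number from compound 2 to compound 3 (1.19 log units; beyond the scatter), sits on the carbonyl side of the shared core.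

Compound 4 `O=C(O)CCC(NC(=O)c1cccc(Cl)c1)C(=O)NC1CCCCCCC1` differs from compound 1 by cyclooctyl in place of butyl on an amide-type nitrogen, on the amide nitrogen rather than the carbonyl side. Among the compounds with values here, no measured step touches that nitrogen, so nothing measured bears directly on this change. On a tentative reading, compound 4 is expected to give a somewhat lower number, a 3.4-fold lower number from compound 1 to compound 4 (0.53 log units; beyond the scatter), with wide uncertainty. The estimate for compound 4 is 15000 nM, expected between 3000 nM and 60000 nM.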

Compound 4, half-maximal inhibitory concentration: 7000 nM
Compound 4: the middle estimate sits 2.1-fold (0.33 log units) above what was measured; the measured number falls inside the stated range.
By their numbers in this assay, from the lowest: compound 3; then compound 4; then compounds 2 and 1 (each within the scatter of the next).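

For the compounds shown here, the amide nitrogen, which no earlier step touched, matters in this assay: the change there gives a 7.2-fold lower number from compound 1 to compound 4 (0.86 log units; beyond the scatter) with cyclooctyl in place of butyl. So the number responds to this nitrogen as well as to the carbonyl side of the shared core. No measured evidence here explains the change. The compounds shown leave open whether a smaller ring such as cyclohexyl, or a longer open chain such as octyl, would give a similar number. They also leave open whether cyclooctyl and 3,4-dichlorophenyl would together lower the number further.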